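One more ring nitrogen on the shared core

A few compounds are considered here, and "the series" means these few. Any claim that something is new, unique, unknown or untested is made for them only; others in the source may bear on it.

Compound 3 `Cc1cc(-n2ccc3ccccc32)c2ncc(CSCCc3ccccc3)n2c1` is one of three compounds compared in an ADME assay on HEL cells (Homo sapiens) for cytotoxicity, with a stated time of 3 days; a higher number here means that more compound is tolerated, a lower number that less compound is tolerated. Compound 1 `Cc1cc(-c2ccoc2)c2ncc(CSCCc3ccccc3)n2c1` gives 64 ug/mL. For compound 2 `Cc1cc(N2CCCC2)c2ncc(CSCCc3ccccc3)n2c1` the result is a limit of the assay, > 100 ug/mL. For compound 3 the result is likewise a limit, > 100 ug/mL. Compound 3 thus sits at the limit of > 100 ug/mL in this assay, at which 2 of the 3 values shown sit, and the step that the two limits leave unreadable from compound 2 to compound 3 cannot be sized. Compound 4 `Cc1cc(-n2ccc3cccnc32)c2ncc(CSCCc3ccccc3)n2c1` differs from compound 3 by a group of 9 heavy atoms (7 carbon, 2 nitrogen; one five-membered aromatic ring with 1 hetero atom, one six-membered aromatic ring with 1 hetero atom) in place of a group of 9 heavy atoms (8 carbon, 1 nitrogen; one five-membered aromatic ring with 1 hetero atom, one six-membered aromatic ring of carbon only), on an aromatic carbon. Going by the values given here, the steps of an at least 1.5-fold higher number from compound 1 to compound 2 (0.19 log units; that floor lies within the scatter) and an at least 1.5-fold higher number from compound 1 to compound 3 (0.19 log units; that floor lies within the scatter) both end at the limit, so no measured step starting from compound 3 can be read in size. Compound 4 is expected to stay at the limit, an estimated step of a number no higher from compound 3 to compound 4 (the limit leaves the size open). Compound 4 is estimated at 100 ug/mL, between 50 ug/mL and 200 ug/mL.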

Compound 4, half-maximal cytotoxic concentration: > 100 ug/mL
Compound 4: a limit, no number (the forecaster's own chance of this, stated with the estimate: 75%); the middle value lies on the limit itself.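

The added ring nitrogen in the group on this aromatic carbon leaves compound 4 at a limit in this assay, as compound 3 was, so this change gives no sign of lower tolerance: the limit of > 100 ug/mL in this assay, at which 3 of the 4 values shown sit. Steps between compounds at the limit cannot be read. Going by these compounds alone, the one readable step is an at least 1.5-fold higher number from compound 1 to compound 4 (0.19 log units; that floor lies within the scatter), which sets no firm order.

Going by these compounds, how far compound 2, compound 3 and compound 4 lie past the limit stays open. So does whether a carboxylic acid or a primary amine on this carbon would give a number.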